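A few compounds are considered here, and "the series" means these few. Any claim that something is new, unique, unknown or untested is made for them only; others in the source may bear on it.

Measured compounds:
Compound 1, `C[C@@H]1C=NN(C(=O)C(C)(C)C)[C@@H]1c1ccccc1`: in an ADME assay on microsomes (Homo sapiens) for metabolic stability (a higher number here means that the compound lasts longer, a lower number that the compound disappears faster), compound 1 gives 0.45 h.
Compound 2, `O=C(C1CCCCC1)N1N=CCC1c1ccccc1`: in this assay compound 2 gives 0.617 h.
Compound 3, `CC(C)(C)C(=O)N1N=CCC1c1ccccn1`: in this assay compound 3 gives > 1.5 h, which is a limit of the assay and not a number.

Compound 2 and compound 1 lie within the usual scatter of each other, so no order can be read between them. Compound 3 sits at the limit of > 1.5 h in this assay, at which 1 of the 3 values shown sits.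

Compound 4, `CC(C)C(=O)N1N=CCC1c1ccccc1`, has not yet been measured in this assay. It differs from compound 2 in one place: isopropyl in place of cyclohexyl on a carbonyl carbon. For the measured compounds named here, no pair of measured compounds shares this change, so the numbers so far give no direction for it. The step of a 1.2-fold lower number from compound 2 to compound 4 (0.09 log units; within the scatter) is expected to stay within the usual scatter. Compound 4 is estimated at 0.5 h, with a likely range from 0.25 h to 1 h.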

Compound 4, half-life: > 1.5 h
Compound 4 gave a limit, no number; the forecaster's own chance of this, stated with the estimate: 10%; at least 3.0-fold (0.47 log units) between middle value and limit.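

Swapping cyclohexyl for isopropyl on a carbonyl carbon gives, in this assay, an at least 2.4-fold higher number from compound 2 to compound 4 (0.38 log units; beyond the scatter). For the compounds shown here, this is the first single change, and it shows that the group at this place can shift the half-life beyond the scatter. The value of compound 4 is a limit of the assay and not a number: the limit of > 1.5 h in this assay, at which 2 of the 4 values shown sit.

As far as these compounds go, the true size of the step therefore stays open. So does the outcome with an amine or a longer straight chain on this carbonyl carbon.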